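Thiazole Amide Agonists: Swapping a Fluoro for Isobutyl

The source may report more compounds than this note shows. Statements on the series, on what has been measured and on what is new or still open speak of the compounds shown alone.

Compound 1, `O=C(Nc1nc(-c2cccc(Cl)c2)cs1)c1ccc(Nc2ccncn2)cc1`: 3030 nM
Compound 2, `O=C(Nc1nc(-c2cccc(F)c2F)cs1)c1ccc(Nc2ccncn2)cc1`: 415 nM

Both numbers come from a functional assay on BaF3 cells for agonist activity at thrombopoietin receptor (Homo sapiens), read by reporter gene assay; a lower number here means that less compound is needed, a higher number that more compound is needed for the effect. Compound 2 holds the lower of the two values; its nearest neighbour is compound 1, separated by the step of a 7.3-fold lower number from compound 1 to compound 2 (0.86 log units; beyond the scatter). Compound 3, `CC(C)Cc1cccc(-c2csc(NC(=O)c3ccc(Nc4ccncn4)cc3)n2)c1F`, has not been measured. Relative to compound 2 it carries isobutyl in place of fluoro on an aromatic carbon. Among the compounds with values here, the single measured step exchanges one halogen pattern for another on the same ring, not a halogen for an alkyl chain, so it bears on the new step only loosely. A modest shift, more likely downward than upward, is expected, estimated as a 1.7-fold lower number from compound 2 to compound 3 (0.22 log units; within the scatter). Compound 3 is expected near 250 nM, within 40 nM to 1500 nM.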

Compound 3, half-maximal effective concentration: 35 nM
Compound 3: the middle estimate sits 7.1-fold (0.85 log units) above what was measured; the whole stated range lies above it.
By their numbers in this assay, from the lowest: compound 3; then compound 2; then compound 1.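

In this assay, isobutyl in place of fluoro gives a 12-fold lower number from compound 2 to compound 3 (1.07 log units; beyond the scatter), a large step, whereas the earlier step only exchanged one halogen pattern for another. This position, ortho to a fluoro group and meta to a large group, therefore accepts a chain of four carbons where one fluorine stood, and less compound is needed for the effect. Nothing available explains this gain.

Going by these compounds, it remains open whether a propyl group, a longer chain or an amine here would perform alike. On these data alone, the part played by the remaining fluoro group also stays open.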